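A Chloro Substituent Added to the Styryl Phenyl Ring

A few compounds are considered here, and "the series" means these few. Any claim that something is new, unique, unknown or untested is made for them only; others in the source may bear on it.

Of the compounds shown here, three built on a shared core have been measured. Compound 1 `O=C1COC(c2ccc(/N=C/c3cccc(Cl)c3)cc2)=NN1` gives in an assay on cells for inhibition of Amine oxidase [flavin-containing] B (Homo sapiens), read by Amplex Red, with a stated time of 30 min (on this read-out higher numbers stand for weaker inhibition and lower numbers for stronger inhibition), a value of 257 nM. Compound 2 `N#CCCN1N=C(c2ccc(NC(=O)c3cccc(Cl)c3)cc2)OCC1=O` gives in this assay a value of 4230 nM. Compound 3 `O=C1COC(c2ccc(/C=C/c3ccccc3)cc2)=NN1` gives in this assay a value of 165 nM, the lowest number of the three, though its gap to compound 1 lies within the scatter, while its gap to compound 2 lies well beyond it.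

Compound 4 `O=C1COC(c2ccc(/C=C/c3ccc(Cl)cc3)cc2)=NN1` differs from compound 3 in one place: chloro in place of hydrogen on an aromatic carbon. Within the data shown here, no measured pair shows this change on its own. Compound 1 also carries a chloro substituent on its outer ring and sits within the scatter of compound 3, so a large step in either direction is not expected. The step from compound 3 to compound 4 is expected to be a 1.4-fold lower number from compound 3 to compound 4 (0.14 log units; within the scatter), which is a change that may not exceed the scatter. Compound 4 is therefore estimated to give in this assay about 120 nM, within a range from 35 nM to 450 nM.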

Compound 4, half-maximal inhibitory concentration: 542 nM
Compound 4: the middle estimate sits 4.5-fold (0.65 log units) below what was measured; measured number outside the range, above it.
By their numbers in this assay, from the lowest: compounds 3 and 1 (each within the scatter of the next); then compound 4; then compound 2.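

In this assay the change from phenyl to 4-chlorophenyl gives a 3.3-fold higher number from compound 3 to compound 4 (0.52 log units; beyond the scatter) and so weakens inhibition at this position, para to a large group. Among these compounds, this is the first step in the set that isolates a single change, since the earlier compounds differ from one another in more than one place and could not show the effect of chloro alone. Nothing available here explains this loss of inhibition.

On these data alone, whether the loss belongs to chloro itself or would follow any group at this position stays open, and fluoro, methoxy or an amine here could separate those readings, as could chloro on another carbon of the same ring. As far as these compounds go, the step also rests on one pair, so whether the same change would act alike with the linker of compound 1 remains unknown.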